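One Added Methyl on Compound 1

A few compounds are considered here, and "the series" means these few. Any claim that something is new, unique, unknown or untested is made for them only; others in the source may bear on it.

Among the compounds with values here, in an in vitro ADME assay on microsomes from liver (Canis lupus familiaris) for metabolic stability (a lower number here means slower removal, a higher number faster removal of the compound), compound 1 (`CCC(CC)[C@@H]1C(=O)N[C@H](C2Cc3ccccc3C2)C(=O)N1[C@@H](C(=O)N1CCOCC1)c1ccc(C)nc1`) gives 5 mL.min-1.g-1 as the higher of the two known numbers, while compound 2 (`CC[C@H](C)[C@@H]1C(=O)N[C@H](C2Cc3ccccc3C2)C(=O)N1[C@@H](C(=O)N(C)C)c1cnc(C)cc1C`) gives 1 mL.min-1.g-1 with a gap beyond the scatter. Compound 3 (`CCC(CC)[C@@H]1C(=O)N[C@H](C2Cc3ccccc3C2)C(=O)N1[C@@H](C(=O)N1CCOCC1)c1ccc(C)nc1C`) departs from compound 1 in one place by methyl in place of hydrogen on an aromatic carbon with methyl in place of hydrogen on an aromatic carbon, turning 6-methylpyridin-3-yl into 2,6-dimethylpyridin-3-yl. Compound 2 differs from compound 1 in several places and offers only a weak guide. Expected is a 1.3-fold lower number from compound 1 to compound 3 (0.10 log units; within the scatter) as a small move toward a lower number, within the scatter. For compound 3 the estimated value is 4 mL.min-1.g-1 with 2 mL.min-1.g-1 to 8 mL.min-1.g-1 as its expected range.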

Compound 3, intrinsic clearance in microsomes: 1 mL.min-1.g-1
Compound 3: middle estimate off by 4.0-fold (0.60 log units), on the high side; the measured number lies below the stated range.
By their numbers in this assay, from the lowest: compounds 2 and 3 (each within the scatter of the next); then compound 1.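

In this assay, methyl in place of hydrogen on an aromatic carbon, next to the ring nitrogen and ortho to a large group, gives a 5.0-fold lower number from compound 1 to compound 3 (0.70 log units; beyond the scatter) and so turns 6-methylpyridin-3-yl into 2,6-dimethylpyridin-3-yl. Within the data shown here, this shows that a single added methyl at this position moves the read-out beyond the scatter, which the earlier compounds, differing in several places, could not show. Nothing at hand explains the step.

On these data alone, whether an ethyl group, a methoxy group or an amine at this position would give a similar number remains open. Also open, as far as these compounds go, is whether the same methyl would give a similar step on a compound differing elsewhere.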